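A few compounds are considered here, and "the series" means these few. Any claim that something is new, unique, unknown or untested is made for them only; others in the source may bear on it.

For the measured compounds named here, in a functional assay on A549 cells (Homo sapiens) for inhibition, read by sulforhodamine B assay, with a stated time of 48 h, tested at 50 uM (on this read-out higher numbers stand for more inhibition of growth at the one concentration tested and lower numbers for less inhibition of growth), compound 2 `COc1ccc([C@@H]2C/C(=N/O)c3cc(CC=C(C)C)c(OC)cc3O2)cc1` gives 66%, the higher of the two numbers so far. This lies beyond the scatter above compound 1 `COc1ccc([C@@H]2C/C(=N/OCc3cn(-c4ccc(O)cc4)nn3)c3cc(CC=C(C)C)c(OC)cc3O2)cc1`, which gives 52%. Still unmeasured is compound 3 `C#CCO/N=C1/C[C@@H](c2ccc(OC)cc2)Oc2cc(OC)c(CC=C(C)C)cc21`. It departs from compound 2 in one place: propargyl in place of hydrogen on an oxygen. Here propargyl stands in place of hydrogen on an oxygen, so hydroxy becomes propargyloxy. Going by the values given here, no measured pair shows this change on its own, so the evidence for it is indirect. Among the compounds with values here, the only guide is compound 1 at 52%, which also has no hydrogen on that oxygen. A modest fall in this assay is therefore expected, near the edge of the usual scatter, and the estimated change is a number 10 percentage points lower from compound 2 to compound 3 (within the scatter). For compound 3 the expected value is 56%, with an estimated range of 38% to 72%.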

Compound 3, percent growth inhibition at one concentration: 64%
Compound 3: the middle estimate sits 8 percentage points below what was measured; measured number inside the range.
By their numbers in this assay, from the lowest: compound 1; then compounds 3 and 2 (each within the scatter of the next).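

In this assay, propargyl in place of hydrogen on the oxygen bound to the double-bonded nitrogen gives a number 2 percentage points lower from compound 2 to compound 3 (within the scatter), so at this position the loss of that hydrogen alone leaves the read-out within the scatter. The lower number earlier seen at this oxygen therefore goes with the 1-(4-hydroxyphenyl)-1H-1,2,3-triazol-4-yl group and not with the missing hydrogen: ethynyl in its place gives a number 12 percentage points higher from compound 1 to compound 3 (beyond the scatter), a modest step. No independent measurement bears on why these numbers behave this way.

As far as these compounds go, whether a plain methyl, a longer alkyl chain or a benzyl group on the same oxygen would also stay level with the hydroxy group remains open. So does whether the triazole would keep this lower number with an unsubstituted phenyl, or with an amine or a carboxylic acid in place of the hydroxy group on its phenyl ring.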